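Extending the Prenyl Chain of Compound 1

The compounds below may be only part of what the source reports. "The series", "measured", "known", "first", "only" and "open" are said of these compounds alone.

Compound 1 `COc1ccc(C(=O)NCCCOc2cc(=O)n(CCCO)c3c2CC(CC=C(C)C)C(C)(C)C3)cc1` gives 55.5% in a functional assay on PANC-1 cells (Homo sapiens) for inhibition, read by MTT assay, with a stated time of 24 h, tested at 10 uM (a lower number here means less inhibition, a higher number more inhibition at the concentration tested (going by the name of the read-out)), the higher of the two numbers measured. Compound 2 `CC(C)=CCC1Cc2c(OCCCOc3ccc(Cl)cc3)cc(=O)n(CCCO)c2CC1(C)C` gives 22.7% in this assay, and the step of a number 32.8 percentage points lower from compound 1 to compound 2 (beyond the scatter) concerns a change at the other end of the chain, not the position altered here. Compound 3 `COc1ccc(C(=O)NCCCOc2cc(=O)n(CCCO)c3c2CC(C/C=C(\C)CCC=C(C)C)C(C)(C)C3)cc1` differs from compound 1 by 3-methylbut-2-en-1-yl in place of hydrogen on a saturated chain carbon bound to a double-bonded chain carbon. Within the data shown here, no measured step touches that position, so the data give no direction; a step within the scatter is expected, a number 5.5 percentage points lower from compound 1 to compound 3 (within the scatter). Compound 3 is therefore estimated at 50%, with a range from 30% to 70%.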

Compound 3, a percentage reported as inhibition, at one concentration (the size of the read-out at that concentration, not a potency): 45.7%
For compound 3 the middle estimate is 4.3 percentage points above the measured one, and the stated range covers the measured number.
By their numbers in this assay, from the lowest: compound 2; then compounds 3 and 1 (each within the scatter of the next).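

Placing the longer 3,7-dimethylocta-2,6-dien-1-yl chain in place of 3-methylbut-2-en-1-yl gives a number 9.8 percentage points lower from compound 1 to compound 3 (within the scatter) in this assay. Among these compounds, this is the first reading at this position, and it shows that the chain can be extended here by a 3-methylbut-2-en-1-yl unit without a step beyond the scatter. Nothing available explains this result. From the compounds shown here alone, whether a chain ending in an amine or a carboxylic acid would fare the same at this position remains open. So does whether the longer chain would give a similar reading alongside the 4-chlorophenoxy end of compound 2.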